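Trimming the amine tail on a shared peroxide core

The source may report more compounds than this note shows. Statements on the series, on what has been measured and on what is new or still open speak of the compounds shown alone.

Three compounds sharing one core have been measured in an ADME assay on the whole organism (strain FVB) for pharmacokinetics, with Mus musculus as the target, read by LC-MS, at a dose of 30 mg/kg by the oral route; a higher number here means more compound in the circulation at the dose given, a lower number less compound in the circulation:

compound 1 `c1cc([C@H]2CC[C@]3(CC2)OOC2(O3)C3CC4CC(C3)CC2C4)ccc1OCCC1CCNCC1` gives 1190 nM
compound 2 `CC1(C)CC(O)(COc2ccc([C@H]3CC[C@]4(CC3)OOC3(O4)C4CC5CC(C4)CC3C5)cc2)CC(C)(C)N1` gives 1000 nM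
compound 3 `CC(C)(O)CNCCCOc1ccc([C@H]2CC[C@]3(CC2)OOC2(O3)C3CC4CC(C3)CC2C4)cc1` gives 1210 nM

The three figures lie close together. The change a 1.0-fold higher number from compound 1 to compound 3 (0.01 log units; within the scatter) and the change a 1.2-fold higher number from compound 2 to compound 3 (0.08 log units; within the scatter) are both within the scatter, as is a 1.2-fold lower number from compound 1 to compound 2 (0.08 log units; within the scatter), so compound 3 cannot be set apart from compound 1 or compound 2 on these numbers.

Compound 4 `NCCCCOc1ccc([C@H]2CC[C@]3(CC2)OOC2(O3)C3CC4CC(C3)CC2C4)cc1` is not yet measured in this assay. It differs from compound 3 in one place: aminomethyl in place of (2-hydroxy-2-methylpropyl)amino on a saturated chain carbon, three bonds along the chain from an oxygen on an aromatic ring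

The two steps that bear on this change are the ones that reshaped the same amine-bearing tail, a 1.0-fold higher number from compound 1 to compound 3 (0.01 log units; within the scatter) and a 1.2-fold higher number from compound 2 to compound 3 (0.08 log units; within the scatter); neither moved the number beyond the scatter. A smaller amine end in compound 4 is therefore expected to leave the number where the other three sit, with no step beyond the scatter: a 1.1-fold lower number from compound 3 to compound 4 (0.04 log units; within the scatter).

For compound 4 the expected value in this assay is 1100 nM, between 500 nM and 2500 nM.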

Compound 4, maximal plasma concentration: 370 nM
The estimate for compound 4 lay 3.0-fold (0.47 log units) above the measured number; the measured number lies below the stated range.
By their numbers in this assay, from the lowest: compound 4; then compounds 2, 1 and 3 (each within the scatter of the next).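

In this assay, among these compounds, the amine end of the tail turns out to matter, since the bare amino group of the 4-aminobutyl tail gives the first change beyond the scatter (a 3.3-fold lower number from compound 3 to compound 4 (0.51 log units; beyond the scatter)). The other two tails, each with carbon groups on the nitrogen, also stand clear of it (a 3.2-fold lower number from compound 1 to compound 4 (0.51 log units; beyond the scatter); a 2.7-fold lower number from compound 2 to compound 4 (0.43 log units; beyond the scatter)), so tails of quite different shape sit together and only compound 4, with nothing on its nitrogen, falls away. No measurement shown here explains this fall.

A methylamino or 2-hydroxyethylamino end on the same chain would show whether one small group on the nitrogen is enough to hold the number, and whether the hydroxyl counts. A shorter chain carrying the same bare amino end would separate the part played by chain length.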